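From hydroxy to heptyloxy on the shared core

This account rests on a few compounds, and the source may have more. Where it says the series, first, only, none or still open, it means among the compounds named here.

Values measured in a functional assay on HT-29 cells (Homo sapiens) for antiproliferative activity, read by sulforhodamine B assay, with a stated time of 72 h (on this read-out lower numbers stand for stronger inhibition and higher numbers for weaker inhibition), are as follows.
Compound 1 `CCCCCCCCc1ccc(CCC(CO)(CO)NC(=O)CCCCCCC)c2ccccc12` gives 22000 nM
Compound 2 `CCCCCCCCc1ccc(CCC(CO)(CO)NC(=O)C(C)CC)c2ccccc12` gives 25600 nM
Compound 3 `CC(=O)NC(CO)(CO)CCc1ccc(O)c2ccccc12` gives > 80000 nM (a limit of the assay, not a number)

Compound 3 has only a limit and no number, and it stands at the limit of > 80000 nM in this assay, at which 1 of the 3 values shown sits, on this scale. Compound 4 `CCCCCCCOc1ccc(CCC(CO)(CO)NC(C)=O)c2ccccc12` keeps the same amide as compound 3 and changes in one place: heptyl in place of hydrogen on an oxygen on an aromatic ring with heptyl in place of hydrogen on an oxygen on an aromatic ring, so hydroxy becomes heptyloxy.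

Among the compounds with values here, no measured step covers this change directly. Within the data shown here, the only measured step, a 1.2-fold higher number from compound 1 to compound 2 (0.07 log units; within the scatter) for a swap on a carbonyl carbon, is small, so the group on the carbonyl is not expected to decide the outcome for compound 4. The closer guide is the long chain on the core of compound 1 and compound 2. Compound 2, with its octyl chain, reaches 25600 nM as a real number, and compound 4 is expected to land near it. The expected step is an at least 2.6-fold lower number from compound 3 to compound 4 (0.42 log units; beyond the scatter) towards stronger inhibition, though its size is uncertain. For compound 4 the estimate is 30000 nM with an expected range of 12000 nM to 80000 nM overall.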

Compound 4, half-maximal inhibitory concentration: 17600 nM
For compound 4 the middle estimate is 1.7-fold (0.23 log units) above the measured one; the measured number falls inside the stated range.
By their numbers in this assay, from the lowest: compounds 4, 1 and 2 (each within the scatter of the next). At a limit, above all of these: compound 3.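

In this assay, placing a heptyl group on the oxygen on an aromatic ring gives an at least 4.5-fold lower number from compound 3 to compound 4 (0.65 log units; beyond the scatter) and so turns a compound without a measured number into one with a real value. Within the data shown here, this is the only measured change at this position, and unlike the earlier swap on a carbonyl carbon, a 1.2-fold higher number from compound 1 to compound 2 (0.07 log units; within the scatter), it lies beyond the scatter. The true size of the step remains unknown, because compound 3 rests on a limit and not on a number: the limit of > 80000 nM in this assay, at which 1 of the 4 values shown sits.

The compounds shown leave open whether a shorter chain on this oxygen, such as methyl or butyl, would already give a measurable value, or whether a longer chain would lower the number further. From the compounds shown here alone, it also remains open how the same position would respond if the heptyl chain ended in an amine or a carboxylic acid, so the result so far speaks only for heptyl in place of hydrogen on the shared core with this amide.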